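A few compounds are considered here, and "the series" means these few. Any claim that something is new, unique, unknown or untested is made for them only; others in the source may bear on it.

In a functional assay on Huh-7 cells (Homo sapiens) for inhibition, read by MTT assay, with a stated time of 72 h (a higher number here means a weaker inhibitor, a lower number a stronger inhibitor), compound 1 `CNC(=O)CCCCCCCn1nc(-c2cnc3[nH]ccc3c2)c2c(N)ncnc21` gives 23500 nM and compound 2 `Nc1ncnc2c1c(-c1cnc3[nH]ccc3c1)nn2CCCCCCCCC(=O)NO` gives 7380 nM as the lower of the two numbers. Compound 3 `Nc1ncnc2c1c(-c1cnc3[nH]ccc3c1)nn2CCCCCC(=O)NO` is still unmeasured. Its difference from compound 2 is hydroxycarbamoyl in place of 3-(hydroxycarbamoyl)propyl on a saturated chain carbon, five bonds along the chain from an aromatic nitrogen and, in words, hydroxycarbamoyl stands in place of 3-(hydroxycarbamoyl)propyl on a saturated chain carbon, five bonds along the chain from an aromatic nitrogen. Within the data shown here, the one measured step that bears on this is a 3.2-fold lower number from compound 1 to compound 2 (0.50 log units; beyond the scatter) and it is modest. That step exchanged the end of the chain, whereas here the hydroxycarbamoyl end stays and the chain shortens, so it offers no direction. No step beyond the scatter is therefore expected in this assay with any confidence. The expected change is a 1.1-fold lower number from compound 2 to compound 3 (0.02 log units; within the scatter) in this estimate. Compound 3 is estimated at 7000 nM with an expected range from 2500 nM to 20000 nM on this evidence.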

Compound 3, half-maximal inhibitory concentration: > 100000 nM
Compound 3: no number, only a limit; the forecaster's own chance of this, stated with the estimate: 10%; middle value at least 14-fold (1.15 log units) from the limit.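

For compound 3 the reading in this assay is a limit of the assay and not a number: the limit of > 100000 nM in this assay, at which 1 of the 3 values shown sits.

With the hydroxycarbamoyl end kept, the length of the chain counts at this place, five bonds along the chain from an aromatic nitrogen: the shortening gives an at least 13-fold higher number from compound 2 to compound 3 (1.13 log units; beyond the scatter), a large step where the earlier exchange of the chain end was modest. The hydroxycarbamoyl end alone therefore does not hold the number down, since the shorter chain carrying it gives an at least 4.2-fold higher number from compound 1 to compound 3 (0.62 log units; beyond the scatter).

The compounds shown leave open how the number runs at chain lengths other than these two, including a longer chain. They also leave open how a carboxylic acid or a primary amide at the chain end would read at either length.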